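The source may report more compounds than this note shows. Statements on the series, on what has been measured and on what is new or still open speak of the compounds shown alone.

Measured so far in a functional assay on A549 cells (Homo sapiens) for cytotoxicity, read by MTT assay, with a stated time of 48 h; on this read-out lower numbers stand for stronger inhibition and higher numbers for weaker inhibition:
compound 1 `COc1ccc(CN(C(=O)Nc2ccc(F)c(Cl)c2)n2cnnc2)cc1OC`, 21000 nM
compound 2 `COc1ccc(CN(C(=O)Nc2ccc(C#N)cc2)n2cnnc2)cc1OC`, a limit of > 50000 nM
compound 3 `COc1cc(CN(C(=O)Nc2ccc(C#N)cc2)n2cnnc2)cc(OC)c1OC`, 20700 nM

In this assay compound 2 gives only a limit, > 50000 nM, and is one of the values sitting at the limit of > 50000 nM in this assay, at which 1 of the 3 values shown sits. Compound 1 and compound 3 both give numbers. The step of an at least 2.3-fold higher number from compound 1 to compound 2 (0.37 log units; beyond the scatter) shows that the cyano-bearing aryl amide was the weaker of the two, and the step of an at least 2.4-fold lower number from compound 2 to compound 3 (0.38 log units; beyond the scatter) shows that an added methoxy on the benzyl side returned a measurable number. Compound 4 `CCc1ccc(NC(=O)N(Cc2ccc(OC)c(OC)c2)n2cnnc2)cc1` differs from compound 2 in ethyl in place of cyano on an aromatic carbon. Among the compounds with values here, of the measured steps, only the one from compound 1 to compound 2 concerns this aryl amide ring; it was at least modest, and its direction places the cyano group on the weaker side. Removing the cyano in favour of ethyl is therefore expected to move compound 4 back toward the number of compound 1, by a step estimated at an at least 1.6-fold lower number from compound 2 to compound 4 (0.22 log units; that floor lies within the scatter), though a reading at the limit remains possible. Compound 4 is expected to give about 30000 nM, within 12000 nM to 80000 nM.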

Compound 4, half-maximal inhibitory concentration: 28400 nM
Estimate against measurement, compound 4: 1.1-fold (0.02 log units) above, within the range that was stated.
By their numbers in this assay, from the lowest: compounds 3, 1 and 4 (each within the scatter of the next). At a limit, above all of these: compound 2.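

Compound 2 is only a limit and not a number in this assay: the limit of > 50000 nM in this assay, at which 1 of the 4 values shown sits. Ethyl in place of cyano at this ring position, para to a large group, gives an at least 1.7-fold lower number from compound 2 to compound 4 (0.24 log units; that floor lies within the scatter) so compound 4 brings this ring back to a measured number, although the size of the change is known only as a floor that cannot be called beyond the scatter. Within the data shown here, the comparison with the halogenated ring, which the earlier compounds could make only for cyano, gives a 1.4-fold higher number from compound 1 to compound 4 (0.13 log units; within the scatter) and so the 4-ethylphenyl and 3-chloro-4-fluorophenyl groups cannot be told apart in this assay.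

The compounds shown cover only cyano and ethyl at this position, so it remains open how an amine, a carboxylic acid, a methoxy or a longer chain such as butyl would read there. From the compounds shown here alone, it is also open whether ethyl would read differently alongside the added methoxy on the benzyl side, where compound 3 with its cyano group gives 20700 nM in this setting.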